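The compounds below may be only part of what the source reports. "The series", "measured", "known", "first", "only" and "open" are said of these compounds alone.

Working notes on the series in an assay on cells for inhibition of cytochrome P450 11B1, mitochondrial (Homo sapiens); on this read-out higher numbers stand for weaker inhibition and lower numbers for stronger inhibition. Compound 1 `CC(C)CC1n2cncc2CN(CC2CC2)S1(=O)=O` gives 122 nM. Within the data shown here, compound 3 `CC(C)CC1n2cncc2CN(C2CC2)S1(=O)=O` gives 930 nM; the only single-point step measured so far is a 7.6-fold higher number from compound 1 to compound 3 (0.88 log units; beyond the scatter), and it lies on the sulfonamide nitrogen of the shared core. Compound 2 `CC(C)CC1n2cncc2CN(Cc2ccc(OC(F)(F)F)cc2)S1(=O)=O`, which carries an aromatic ring on that nitrogen, gives 544 nM in this assay. Among the three numbers compound 2 stands second highest: it is within the scatter of compound 3 and beyond the scatter of compound 1, the latter being the lower number.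

Compound 4 `CC(C)CC1n2cncc2CN(Cc2ccc(F)cc2)S1(=O)=O` is not yet measured. It differs from compound 2 in one place only, on the aromatic ring: fluoro in place of trifluoromethoxy on an aromatic carbon. Among the measured compounds shown here, nothing measured so far bears directly on this change. For the measured compounds named here, the one step on record, from compound 1 to compound 3, concerns the group on the sulfonamide nitrogen, not the aromatic ring, so it gives no direct guide to the size or direction of the new step. Going by the values given here, with no relevant precedent the step is expected to be a 1.2-fold lower number from compound 2 to compound 4 (0.08 log units; within the scatter), that is, nothing beyond the scatter in this assay. Compound 4 is accordingly estimated at 450 nM, with a range from 150 nM to 1400 nM in this assay.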

Compound 4, half-maximal inhibitory concentration: 26.1 nM
Compound 4: middle estimate off by 17-fold (1.24 log units), on the high side; measured number outside the range, below it.
By their numbers in this assay, from the lowest: compound 4; then compound 1; then compounds 2 and 3 (each within the scatter of the next).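

Working notes, continued. In this assay the aromatic ring carries a substituent that matters strongly: fluoro in place of trifluoromethoxy, on an aromatic carbon para to a large group, gives a 21-fold lower number from compound 2 to compound 4 (1.32 log units; beyond the scatter), a larger step than the one on the sulfonamide nitrogen measured earlier. An aromatic ring on that nitrogen can therefore sit on either side of the cyclopropylmethyl of compound 1: 4-fluorophenyl in place of cyclopropyl on the saturated chain carbon gives a 4.7-fold lower number from compound 1 to compound 4 (0.67 log units; beyond the scatter), whereas compound 2 at 544 nM lies on the higher side of compound 1 at 122 nM, so the outcome of placing an aromatic ring there turns on what that ring carries. Nothing at hand accounts for the size of either step.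

With only two substituents shown on this aromatic carbon, it remains open where a bare hydrogen, a chloro, a methoxy or a nitrile would fall relative to fluoro and trifluoromethoxy. Also open, from the compounds shown here alone, is whether the low number of compound 4 would survive a longer chain between the aromatic ring and the sulfonamide nitrogen.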